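Replacing an Aromatic Ring with a Short Alcohol Chain

The compounds below may be only part of what the source reports. "The series", "measured", "known", "first", "only" and "open" are said of these compounds alone.

Compound 1 `O=C1O/C(=C\Cn2cc(-c3cc(F)cc(F)c3)nn2)C(OCc2ccccc2)=C1OCc1ccccc1`: > 100000 nM
Compound 2 `COc1ccccc1-c1cn(C[C@H](O)[C@H]2OC(=O)C(OCc3ccccc3)=C2OCc2ccccc2)nn1`: > 100000 nM

Both compounds were tested in a functional assay on SW-620 cells (Homo sapiens) for antiproliferative activity, read by MTT assay, with a stated time of 72 h; a higher number here means a weaker inhibitor, a lower number a stronger inhibitor. For compound 1 the value > 100000 nM is a limit of the assay rather than a number. For compound 2 the value > 100000 nM is likewise a limit. Compound 2 thus sits at the limit of > 100000 nM in this assay, at which 2 of the 2 values shown sit, showing no measurable inhibition. Compound 3 `O=C1O[C@H]([C@@H](O)Cn2cc(CCO)nn2)C(OCc2ccccc2)=C1OCc1ccccc1` differs from compound 2 by a single change: 2-hydroxyethyl in place of 2-methoxyphenyl on an aromatic carbon. Within the data shown here, with no measured step between compounds to lean on, the expectation for a number no higher from compound 2 to compound 3 (the limit leaves the size open) is no shift beyond the scatter. Compound 3 is therefore estimated at 100000 nM, between 30000 nM and 300000 nM, and will most likely again be reported only as a limit.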

Compound 3, half-maximal inhibitory concentration: > 100000 nM
Compound 3: no number, only a limit; the forecaster's own chance of this, stated with the estimate: 85%; the middle value sits exactly at the limit.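

The step from compound 2 to compound 3 cannot be read, since each is reported only as a limit: the limit of > 100000 nM in this assay, at which 3 of the 3 values shown sit.

The compounds shown leave open which structural change, if any, would give a measurable value in this assay.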